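Amide side-chain amines and maximal response at the receptor

The source may hold more compounds than are shown below. What is called first, only, known or untested is meant among the compounds shown, and "the series" means these compounds.

Measured so far:
compound 1 `COc1cc(N)c(Cl)cc1C(=O)NCC1CCNCC1` — 81%
compound 2 `COc1cc(N)c(Cl)cc1C(=O)NC1CCNCC1` — > 100%

For the measured compounds named here, in a functional assay on HEK293 cells for activation of 5-hydroxytryptamine receptor 4 (Homo sapiens), read by cAMP accumulation (on this read-out lower numbers stand for smaller maximal responses and higher numbers for larger maximal responses), compound 1 gives 81% and stands as the only plain number among the two values measured. The value of compound 2 in this assay, > 100%, is a limit of the read-out and not a number (the limit of > 100% in this assay, at which 1 of the 2 values shown sits). Going by the values given here, no step between two measured compounds differing in one place is available, so the pair supports no comparison of size.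

Compound 3 `COc1cc(N)c(Cl)cc1C(=O)NCCN1CCNCC1` differs from compound 1 by (piperazin-1-yl)methyl in place of piperidin-4-yl on a saturated chain carbon bound to an amide-type nitrogen. The saturated chain carbon bound to the amide-type nitrogen keeps a basic ring at its end, now carrying a second hetero atom and one further hydrogen-bond acceptor.

Among the compounds with values here, with no measured step to lean on, the expected step of a number 4 percentage points higher from compound 1 to compound 3 (within the scatter) is small and within the usual scatter, in neither direction beyond it. Compound 3 is estimated at 85% in this assay, with a range from 62% to 105%.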

Compound 3, intrinsic activity: the largest response reached, in percent of the reference agonist's: > 100%
Compound 3: no number, only a limit (the forecaster's own chance of this, stated with the estimate: 20%); at least 15 percentage points between middle value and limit.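

The change to (piperazin-1-yl)methyl in place of piperidin-4-yl, on a saturated chain carbon bound to an amide-type nitrogen, gives the series its first readable step in this assay: a number at least 19 percentage points higher from compound 1 to compound 3 (beyond the scatter). In this assay compound 3 gives > 100%, which is a limit and not a number, so the step has a lower bound but no upper one. Further gains at this position cannot be sized on this read-out: the limit of > 100% in this assay, at which 2 of the 3 values shown sit.

This change alters the ring's hetero atoms and its attachment to the chain together, and the compounds shown do not separate the two. From the compounds shown here alone, a (piperidin-1-yl)methyl or (morpholin-4-yl)methyl group at the same place would bear on that question, but how either would read out remains open.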